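Cytotoxicity notes on a substituted imidazolylmethyl-aminobenzoate series

A few compounds are considered here, and "the series" means these few. Any claim that something is new, unique, unknown or untested is made for them only; others in the source may bear on it.

Measured so far in a toxicity assay on NIH3T3 cells (Mus musculus) for cytotoxicity, read by resazurin assay; on this read-out lower numbers stand for an effect already at smaller amounts and higher numbers for an effect only at larger amounts of compound:
compound 1 `COC(=O)c1ccc(NCc2cncn2Cc2ccc(Cl)cc2)cc1-c1ccccc1`, 25000 nM
compound 2 `COC(=O)c1ccc(NCc2cncn2Cc2ccccc2C)cc1-c1ccccc1`, 10000 nM
compound 3 `N#Cc1ccc(NCc2cncn2Cc2ccc(-c3ccccc3)cc2N)cc1-c1ccccc1`; its value is a limit of this assay, > 1000 nM

Compound 2 holds the lowest of the two numbers shown, the nearest being compound 1, which sits at a 2.5-fold lower number from compound 1 to compound 2 (0.40 log units; beyond the scatter) in the reverse direction. Within the data shown here, the only step measured between two compounds differing in one place is a 2.5-fold lower number from compound 1 to compound 2 (0.40 log units; beyond the scatter), a modest step beyond the scatter at the same position as the change now under consideration. Among the measured compounds shown here, the third compound, with its limit (the limit of > 1000 nM in this assay, at which 1 of the 3 values shown sits), is changed in several places at once and gives no number, so it supports no step.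

The next compound, compound 4 `COC(=O)c1ccc(NCc2cncn2Cc2ccc(-c3ccccc3)cc2)cc1-c1ccccc1`, is not yet measured. Against compound 2 the change is 4-phenylphenyl in place of 2-methylphenyl on a saturated chain carbon bound to an aromatic nitrogen.

For the measured compounds named here, the one measured step at this position points downward but is modest, and nothing else bears on an exchange of this size, so the expectation for this step is weak. For compound 4 a number somewhat lower than that of compound 2 is expected, 6000 nM, with a range of 2000 nM to 25000 nM; this estimate means a 1.7-fold lower number from compound 2 to compound 4 (0.22 log units; within the scatter).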

Compound 4, half-maximal effective concentration: > 1000 nM
Compound 4: no number, only a limit; the forecaster's own chance of this, stated with the estimate: 25%; the middle value is on the limit's open side.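

In this assay compound 4 gives only a limit (> 1000 nM) and not a number, so the steps to it from compound 2 and from compound 1 cannot be read. The compounds shown leave open whether the number in this assay shifts at all with 4-phenylphenyl in place of 2-methylphenyl or with phenyl in place of chloro.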